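The source may hold more compounds than are shown below. What is called first, only, known or untested is meant among the compounds shown, and "the series" means these compounds.

Compound 1 `Cc1ccc(S(=O)(=O)N[C@@H](CC(=O)NC(C)(C)C)C(=O)NCCNC(=O)c2ccccc2F)cc1` and compound 2 `Cc1ccc(S(=O)(=O)N[C@@H](CC(=O)NC(C)(C)C)C(=O)NCCNC(=O)c2ccc(F)cc2)cc1` share their core with compound 3 `Cc1ccc(S(=O)(=O)N[C@@H](CC(=O)NC(C)(C)C)C(=O)NCCNC(=O)c2cc(Cl)ccc2Cl)cc1` and differ from it only in the group on a carbonyl carbon. In an ADME assay on Karpas-1106P cells (Homo sapiens) for cytotoxicity (a higher number here means that more compound is needed for the effect, a lower number that less compound is needed), compound 1 gives > 11100 nM as a limit of the assay and not a number. Compound 2 gives > 11100 nM and this too is a limit. Compound 3 gives > 11100 nM as a limit as well. All three therefore rest on the limit of > 11100 nM in this assay, at which 3 of the 3 values shown sit, and no actual number is available for any of them.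

Compound 4 `Cc1ccc(S(=O)(=O)N[C@@H](CC(=O)NC(C)(C)C)C(=O)NCCNS(=O)(=O)c2ccccc2)cc1` makes a different kind of change, with phenylsulfonyl in place of (2,5-dichlorophenyl)carbonyl on an amine nitrogen and phenylsulfonyl in place of (2,5-dichlorophenyl)carbonyl on an amine nitrogen as its count. The measured steps bear on this only loosely, since each one swaps the group on the carbonyl carbon and none replaces the carbonyl itself. They yield a step that the two limits leave unreadable from compound 1 to compound 2 and then a step that the two limits leave unreadable from compound 1 to compound 3 and finally a step that the two limits leave unreadable from compound 2 to compound 3 as their whole evidence, so none has a size to carry forward. No direction can be forecast, and the most likely outcome is another reading at the limit. The expected step is a step that the limit leaves unreadable from compound 3 to compound 4 on this reasoning, with no change beyond the scatter foreseen. For compound 4 the estimate is 12000 nM with an expected range from 6000 nM to 30000 nM in this assay as the assay reads it.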

Compound 4, half-maximal effective concentration: > 11100 nM
Compound 4 gave a limit, no number (the forecaster's own chance of this, stated with the estimate: 85%); the middle value lies beyond the limit too.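

Compound 4 gives a limit of the assay and not a number, so its steps from compound 1, compound 2 and compound 3 cannot be read, and the four compounds rest on a single reading: the limit of > 11100 nM in this assay, at which 4 of the 4 values shown sit. The compounds shown leave open whether any of them has a measurable effect in this assay and whether phenylsulfonyl in place of a substituted phenylcarbonyl changes it.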